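A few compounds are considered here, and "the series" means these few. Any claim that something is new, unique, unknown or untested is made for them only; others in the source may bear on it.

Working notes on the series. Compound 1 `Cc1cc(-c2ccccc2NCC2=NCCN2)on1` carries a 3-methyl-1,2-oxazol-5-yl group on the shared core. In a functional assay for activation of Alpha-1D adrenergic receptor (Homo sapiens) (on this read-out lower numbers stand for an effect already at smaller amounts and higher numbers for an effect only at larger amounts of compound), compound 1 gives only a limit, < 100000 nM. Compound 2 `c1ccc(-c2cnoc2)c(NCC2=NCCN2)c1` differs from it by 1,2-oxazol-4-yl in place of 3-methyl-1,2-oxazol-5-yl on an aromatic carbon. In this assay compound 2 likewise gives only a limit, < 100000 nM. The step that the two limits leave unreadable from compound 1 to compound 2 cannot be read, since both values sit at the same limit (the limit of < 100000 nM in this assay, at which 2 of the 2 values shown sit). Compound 2 therefore stands at that limit and nowhere more definite on the numbers available.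

Compound 3 `Cc1ccsc1-c1ccccc1NCC1=NCCN1` is not yet measured; the change is 3-methylthiophen-2-yl in place of 1,2-oxazol-4-yl on an aromatic carbon. Among the compounds with values here, no measured step bears on this change with a readable size, as the single recorded step is unreadable. The expected step from compound 2 to compound 3 is accordingly a step that the limit leaves unreadable from compound 2 to compound 3, set without support from any readable comparison. For compound 3 the estimate in this assay is 1000 nM, with a range from 30 nM to 30000 nM.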

Compound 3, half-maximal effective concentration: 49 nM
Compound 3: the middle estimate sits 20-fold (1.31 log units) above what was measured; low and high end bracket the measured number.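

Within the data shown here, no step to compound 3 can be read from compound 1 or compound 2, because each of those two values is only a limit: the limit of < 100000 nM in this assay, at which 2 of the 3 values shown sit.

The compounds shown leave open how far compound 1 and compound 2 truly lie from compound 3, and whether the methyl or the thiophene part of 3-methylthiophen-2-yl goes with its value.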